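Nitro to trifluoromethyl on the anilino ring of compound 2

The compounds below may be only part of what the source reports. "The series", "measured", "known", "first", "only" and "open" are said of these compounds alone.

Measured so far:
compound 1 `CC(=O)N(c1ccc(O)cc1)c1sc2ccccc2c1C#N` — 59%
compound 2 `N#Cc1c(Nc2ccc([N+](=O)[O-])cc2)sc2ccccc12` — 37%
compound 3 `COc1cc2sc(Nc3ccc(O)cc3)c(C#N)c2cc1OC` — 73%

All three numbers come from a functional assay on HUVEC cells (Homo sapiens), read by fluorescence and microscopy, with a stated time of 6 h, tested at 250 nM; a lower number here means a stronger effect, a higher number a weaker effect of the compound at the concentration tested. Compound 2 gives the lowest number of the three; compound 1 stands nearest to it and compound 3 furthest, and both of those gaps lie beyond the usual scatter, so compound 2 shows the strongest effect of the set. Compound 4 `N#Cc1c(Nc2ccc(C(F)(F)F)cc2)sc2ccccc12` has not yet been measured. It differs from compound 2 in one place: trifluoromethyl in place of nitro on an aromatic carbon. Among the measured compounds shown here, no pair of measured compounds differs in exactly this way, so nothing shows directly what this exchange does.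

Compound 4 is expected to give 45%, with a range from 25% to 65%. The step of a number 8 percentage points higher from compound 2 to compound 4 (within the scatter) is estimated to be small, toward a slightly weaker effect, and not beyond the scatter of this assay.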

Compound 4, a percentage reported as activity, at one concentration (the size of the read-out at that concentration, not a potency): 65%
For compound 4 the middle estimate is 20 percentage points below the measured one; the range from low to high includes it.
By their numbers in this assay, from the lowest: compound 2; then compounds 1, 4 and 3 (each within the scatter of the next, the first and the last beyond it).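

In this assay, among the compounds shown here, trifluoromethyl in place of nitro on this aromatic carbon gives a number 28 percentage points higher from compound 2 to compound 4 (beyond the scatter), the first reading of a single change. The position para to a large group is therefore not indifferent to the group it carries, and here nitro goes with the stronger effect at the concentration tested. No available measurement bears on what lies behind this step.

One exchange cannot show whether the stronger effect is particular to nitro or would also appear with other groups on this carbon, such as an amine or a carboxylic acid. On these data alone, it is also open whether the same step would appear on the dimethoxy-substituted core of compound 3, which differs from compound 2 in more than one place.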